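The source may hold more compounds than are shown below. What is called first, only, known or untested is meant among the compounds shown, and "the series" means these compounds.

In a functional assay on MGC-803 cells (Homo sapiens) for cytotoxicity, read by MTT assay, with a stated time of 48 h (on this read-out higher numbers stand for weaker inhibition and lower numbers for stronger inhibition), two compounds with the same core have been tested so far. Compound 1 (`Cc1ccc(C(=O)N2N=C(c3cc4ccccc4oc3=O)CC2c2ccccc2)cc1`) gives 31300 nM. Compound 2 (`O=C(CN1CCCC1)N1N=C(c2cc3ccccc3oc2=O)CC1c1ccccc1`) is reported as "not active" (no number reported), so it stands without a single number and offers no exact starting point. Compound 3 (`CC1CCCN(CC(=O)N2N=C(c3cc4ccccc4oc3=O)CC2c2ccccc2)C1`) has not yet been measured. It carries 3-methylpiperidin-1-yl in place of pyrrolidin-1-yl on a saturated chain carbon bound to a carbonyl carbon. For the measured compounds named here, no measured pair shows what a single change of this kind does in this assay. Only a modest step towards stronger inhibition is expected from this exchange, and a second "not active" report remains quite possible. Any number that does appear is expected to lie near that of compound 1 at 31300 nM. Compound 3 is estimated at 45000 nM, with an expected range from 18000 nM to 100000 nM.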

Compound 3, half-maximal inhibitory concentration: "not active" (no number reported)
No number was reported for compound 3; the estimate stays without a comparison.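

Compound 2 and compound 3 are both reported as "not active" without a number, so no step can be read between them. The compounds shown leave open what exchanging pyrrolidin-1-yl for 3-methylpiperidin-1-yl does to inhibition in this series. No evidence bearing on this result is available.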